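The source may hold more compounds than are shown below. What is called first, only, known or untested is meant among the compounds shown, and "the series" means these compounds.

Compound 1 `O=C1Nc2ccccc2/C1=N/NC(=S)Nc1ccccc1` and compound 2 `O=C(N/N=C1\C(=O)Nc2ccccc21)Nc1ccccc1` are close relatives built on the same core. In an ADME assay on RD cells (Homo sapiens) for cytotoxicity (on this read-out higher numbers stand for lower toxicity in this test and lower numbers for higher toxicity in this test), compound 1 reaches only the limit of the test, > 25000 nM. In this assay compound 2 likewise gives a limit and no number, > 25000 nM. Both results therefore sit at the limit of > 25000 nM in this assay, at which 2 of the 2 values shown sit. Compound 3 `Cc1ccc(NC(=O)N/N=C2\C(=O)Nc3ccccc32)cc1` differs from compound 2 by methyl in place of hydrogen on an aromatic carbon, in words methyl in place of hydrogen on an aromatic carbon. Among the measured compounds shown here, no measured step of this kind is at hand. The step from compound 2 to compound 3 is expected to stay within the scatter, a step that the limit leaves unreadable from compound 2 to compound 3. Compound 3 is accordingly estimated at 30000 nM, between 10000 nM and 100000 nM.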

Compound 3, half-maximal cytotoxic concentration: > 25000 nM
Compound 3: only a limit was reported; the forecaster's own chance of this, stated with the estimate: 75%; the middle value does not contradict the limit.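

No step can be read from compound 2 to compound 3, as each result is only a limit: the limit of > 25000 nM in this assay, at which 3 of the 3 values shown sit. The compounds shown leave open what methyl in place of hydrogen on an aromatic carbon does in this assay.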